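The source may report more compounds than this note shows. Statements on the series, on what has been measured and on what is new or still open speak of the compounds shown alone.

Measured so far in a functional assay on HUVEC cells (Homo sapiens), read by scintillation counting and thymidine incorporation, with a stated time of 24 h; a lower number here means a stronger inhibitor, a higher number a weaker inhibitor:

compound 1 `CCC(C)n1ncn(-c2ccc(N3CCN(c4ccc(OC[C@@H]5CO[C@@](CN(C)C)(c6ccc(Cl)cc6Cl)O5)cc4)CC3)cc2)c1=O`: 1400 nM
compound 2 `CCc1nccn1C[C@@]1(c2ccc(Cl)cc2Cl)OC[C@@H](COc2ccc(N3CCN(c4ccc(-n5cnn(C(C)CC)c5=O)cc4)CC3)cc2)O1`: 224 nM
compound 3 `CCC(C)n1ncn(-c2ccc(N3CCN(c4ccc(OC[C@@H]5CO[C@@](Cn6ccnc6-c6ccccc6)(c6ccc(Cl)cc6Cl)O5)cc4)CC3)cc2)c1=O`: 136 nM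

Compound 3 carries the lowest of the three numbers, but its lead over compound 2 is not meaningful: a 1.6-fold lower number from compound 2 to compound 3 (0.22 log units; within the scatter). Compound 3 stands well clear of compound 1, as a 10-fold lower number from compound 1 to compound 3 (1.01 log units; beyond the scatter) shows.

Compound 4 `CCC(C)n1ncn(-c2ccc(N3CCN(c4ccc(OC[C@@H]5CO[C@@](Cn6cc(C)nc6C)(c6ccc(Cl)cc6Cl)O5)cc4)CC3)cc2)c1=O` has 2,4-dimethyl-1H-imidazol-1-yl in place of 2-phenyl-1H-imidazol-1-yl on a saturated chain carbon bound to a saturated ring carbon.

Compound 4 keeps an imidazolyl group, so the large gain seen with a 10-fold lower number from compound 1 to compound 3 (1.01 log units; beyond the scatter) and the modest one seen with a 6.3-fold lower number from compound 1 to compound 2 (0.80 log units; beyond the scatter) are not what is being tested here. Within the data shown here, the closest precedent is a 1.6-fold lower number from compound 2 to compound 3 (0.22 log units; within the scatter), where phenyl in place of ethyl on an aromatic carbon moved the number by less than the scatter. Compound 4, like compound 2, has alkyl rather than phenyl on the imidazole, which points to a value near the 224 nM of compound 2. Among the measured compounds shown here, no measured compound has a counterpart to the second methyl group, so the range stays wide.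

The expected step is a 1.7-fold higher number from compound 3 to compound 4 (0.23 log units; within the scatter), a slightly higher number.

For compound 4 the estimated value in this assay is 230 nM, with an expected range of 100 nM to 550 nM.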

Compound 4, half-maximal inhibitory concentration: 492 nM
Beside the measured number, compound 4's estimate is 2.1-fold (0.33 log units) below it, and the stated range covers the measured number.
By their numbers in this assay, from the lowest: compounds 3 and 2 (each within the scatter of the next); then compound 4; then compound 1.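

In this assay, the group on the saturated chain carbon bound to a saturated ring carbon now separates one imidazolyl group from another: a 3.6-fold higher number from compound 3 to compound 4 (0.56 log units; beyond the scatter) and a 2.2-fold higher number from compound 2 to compound 4 (0.34 log units; beyond the scatter) both lie beyond the scatter, whereas the 2-ethyl-1H-imidazol-1-yl and 2-phenyl-1H-imidazol-1-yl groups of compound 2 and compound 3 stayed within it. The 2,4-dimethyl-1H-imidazol-1-yl group still holds part of the gain over dimethylamino, with a 2.8-fold lower number from compound 1 to compound 4 (0.45 log units; beyond the scatter) as the step, so all three imidazolyl compounds stand lower than compound 1, but the size of that gain depends on what the imidazole carries. Nothing available here accounts for this ordering.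

Compound 2 and compound 4 differ in both the alkyl group and the extra methyl, so the series leaves open which of the two sets the gap, and a 2-methyl-1H-imidazol-1-yl or unsubstituted 1H-imidazol-1-yl group would separate them. Also open, on these data alone, is whether a different ring at this place, such as a 1,2,4-triazol-1-yl or morpholin-4-yl group, would hold the gain seen with the imidazolyl groups.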